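Cyclopropyl to phenyl on the sulfonyl sulfur

A few compounds are considered here, and "the series" means these few. Any claim that something is new, unique, unknown or untested is made for them only; others in the source may bear on it.

Measured in an ADME assay (liver) for metabolic stability, with Liver microsome (Homo sapiens) as the target, read by LC-MS, using microsomes and NADPH, with a stated time of 5 min, at 37 degrees C; a lower number here means slower removal, a higher number faster removal of the compound:
- Compound 1 `CCn1c([C@@H](C)NS(=O)(=O)c2ccc(Cl)cc2)nc2cc(CO)ccc21`: 88 mL.min-1.g-1
- Compound 2 `CCn1c([C@@H](C)NS(=O)(=O)c2ccc(Cl)cc2)nc2cccc(Cl)c21`: > 100 mL.min-1.g-1 (a limit)
- Compound 3 `CCn1c([C@@H](C)NS(=O)(=O)C2CC2)nc2ccc(C(F)(F)F)cc21`: < 3 mL.min-1.g-1 (a limit)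

Compound 3 stands at the limit of < 3 mL.min-1.g-1 in this assay, at which 1 of the 3 values shown sits. Its true value is therefore unknown, and any comparison with it is only one-sided. Compound 2 stands at the limit of > 100 mL.min-1.g-1 in this assay, at which 1 of the 3 values shown sits, the opposite limit.

Compound 4 `CCn1c([C@@H](C)NS(=O)(=O)c2ccccc2)nc2ccc(C(F)(F)F)cc21` keeps the core of compound 3 and has phenyl in place of cyclopropyl on a sulfonyl sulfur. For the measured compounds named here, no measured pair isolates this change. Compound 1, at 88 mL.min-1.g-1, also has an aromatic ring on the sulfonyl sulfur, although that ring carries chlorine and the core differs. This gives weak support for a sizeable upward move in this assay. The estimated step is an at least 8.3-fold higher number from compound 3 to compound 4 (0.92 log units; beyond the scatter), and its size remains uncertain. For compound 4 the expected value is 25 mL.min-1.g-1, with an estimated range of 7 mL.min-1.g-1 to 75 mL.min-1.g-1.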

Compound 4, intrinsic clearance in microsomes: 14 mL.min-1.g-1
Estimate against measurement, compound 4: 1.8-fold (0.25 log units) above; the measured number falls inside the stated range.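

For the compounds shown here, with the core of compound 3 held fixed, phenyl in place of cyclopropyl on the sulfonyl sulfur is the first change isolated at one place, and in this assay it gives an at least 4.6-fold higher number from compound 3 to compound 4 (0.66 log units; beyond the scatter). Only the lower bound of this step is known, because compound 3 is a limit value: the limit of < 3 mL.min-1.g-1 in this assay, at which 1 of the 4 values shown sits. Compound 4 has a measured number rather than a limit, so on this core the phenyl compound offers a reference point that can be read in both directions.

Compound 1 and compound 2 differ from compound 4 in more than one place, so the contribution of chlorine on the phenyl ring on this core remains unresolved. Also open, as far as these compounds go, is how a methyl group or a pyridyl ring on the sulfonyl sulfur would read.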